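This account rests on a few compounds, and the source may have more. Where it says the series, first, only, none or still open, it means among the compounds named here.

Measured compounds:
compound 1, `Cc1cc(/C=C/C(=O)NCCn2c(C)cc3ccccc32)cc(C)c1F`: < 25000 nM
compound 2, `Cc1cc2ccccc2n1CCNC(=O)/C=C/c1ccc(OCCCO)cc1`: 66000 nM
compound 3, `COc1cc(/C=C/C(=O)NCCn2c(C)cc3ccccc32)cc(OC)c1`: < 25000 nM

Compound 3 stands at a limit of a physicochemical assay for solubility, read by nephelometry, in phosphate buffer, at pH 7.4; a higher number here means a more soluble compound, a lower number a less soluble compound: its reading of < 25000 nM is a bound of the method, not a number. Compound 1 sits at the same limit, with < 25000 nM. Only compound 2 returns a measured value, 66000 nM. Two of the three readings therefore rest on (the limit of < 25000 nM in this assay, at which 2 of the 3 values shown sit), and no ordering among the three can be drawn from them.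

Compound 4, `COc1cc(/C=C/C(=O)NCCn2c(C)cc3ccccc32)cc(OC)c1OCCO`, differs from compound 3 by 2-hydroxyethoxy in place of hydrogen on an aromatic carbon.

For the measured compounds named here, no step between measured compounds is available to calibrate this change. Going by the values given here, compound 2, the one member with a number of its own, reads 66000 nM; against that background the change to compound 4 is expected to raise solubility, with a step of an at least 2.0-fold higher number from compound 3 to compound 4 (0.30 log units; that floor lies within the scatter) estimated to exceed the usual scatter. The starting point of that step is itself only a limit, so its true size is open. Compound 4 is expected to come in at 50000 nM, within a range of 20000 nM to 130000 nM; a reading that again stops at the limit is not ruled out.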

Compound 4, solubility: 66000 nM
Compound 4: the middle estimate sits 1.3-fold (0.12 log units) below what was measured; low and high end bracket the measured number.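

Notes on the position: in this assay, this aromatic carbon, ortho to two methoxy groups and para to a large group, accepts 2-hydroxyethoxy in place of hydrogen, and the pair gives a readable step for the change, an at least 2.6-fold higher number from compound 3 to compound 4 (0.42 log units; beyond the scatter), printed as beyond the usual scatter. Compound 3 reads < 25000 nM, which is a limit of the method and not a number. The step is therefore a floor rather than a size, and its true extent stays open because it starts from a limit: the limit of < 25000 nM in this assay, at which 2 of the 4 values shown sit.

From the compounds shown here alone, whether this step is specific to 2-hydroxyethoxy remains open, since no other group at this position can be compared directly, whether a 2-aminoethoxy chain carrying an amine, a carboxymethoxy group carrying a carboxylic acid, or a longer chain such as 4-hydroxybutoxy. Also open, going by these compounds, is whether the same change gives a step of this kind on another substitution pattern, such as the dimethyl and fluoro pattern of compound 1.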